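A few compounds are considered here, and "the series" means these few. Any claim that something is new, unique, unknown or untested is made for them only; others in the source may bear on it.

Compound 3 `O=C(O)c1cccc(-c2ccc(/C=C3\S/C(=N\c4ccccc4)N(c4ncccc4F)C3=O)o2)c1` is one of three measured members of a shared core. In an ADME assay on Vero cells (Chlorocebus sabaeus) for cytotoxicity (on this read-out higher numbers stand for lower toxicity in this test and lower numbers for higher toxicity in this test), compound 3 gives > 200000 nM, which is a limit of the assay and not a number. In this assay compound 1 `O=C(O)c1cccc(-c2ccc(/C=C3\S/C(=N\c4ccc(F)cc4)N(c4ccc(F)cc4)C3=O)o2)c1` gives > 200000 nM, also a limit. In this assay compound 2 `O=C(O)c1cccc(-c2ccc(/C=C3\S/C(=N\c4ccc(Cl)cc4)N(c4ncccc4F)C3=O)o2)c1` gives > 200000 nM, again a limit. The step that the two limits leave unreadable from compound 2 to compound 3 therefore cannot be read, since (the limit of > 200000 nM in this assay, at which 3 of the 3 values shown sit). Compound 4 `O=C(O)c1cccc(-c2ccc(/C=C3\S/C(=N\c4ccccc4)N(c4cccnc4Cl)C3=O)o2)c1` differs from compound 3 by 2-chloropyridin-3-yl in place of 3-fluoropyridin-2-yl on an amide-type nitrogen in a ring. Among the compounds with values here, no measured step bears on this change, so no shift beyond the scatter is expected in this assay. Compound 4 is therefore expected to sit near 200000 nM, between 100000 nM and 400000 nM, most likely reported again only as a limit, an expected step of a number no higher from compound 3 to compound 4 (the limit leaves the size open).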

Compound 4, half-maximal cytotoxic concentration: > 200000 nM
Compound 4 was reported as a limit (the forecaster's own chance of this, stated with the estimate: 85%); the middle value lies on the limit itself.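

The step from compound 3 to compound 4 cannot be read, because both results are limits and not numbers: the limit of > 200000 nM in this assay, at which 4 of the 4 values shown sit.

The compounds shown leave open whether 2-chloropyridin-3-yl in place of 3-fluoropyridin-2-yl changes the read-out in this assay at all.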